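The source may hold more compounds than are shown below. What is called first, only, known or untested is meant among the compounds shown, and "the series" means these compounds.

Compound 1 (`CN1C(=O)/C(=C2\Nc3ccccc3\C2=N/O)c2ccccc21`) gives > 100000 nM in a functional assay on LoVo cells (Homo sapiens) for inhibition, read by MTT assay (on this read-out lower numbers stand for stronger inhibition and higher numbers for weaker inhibition), and this value is a limit of the assay. Going by the values given here, compound 2 (`CCN1C(=O)/C(=C2\Nc3ccccc3\C2=N/O)c2ccccc21`) gives 8490 nM in this assay and holds the only actual number so far. Compound 3 (`CCCN1C(=O)/C(=C2\Nc3ccccc3\C2=N/O)c2ccccc21`) carries one change from compound 2: methyl in place of hydrogen on a saturated chain carbon, two bonds along the chain from an amide-type nitrogen in a ring on the chain, ethyl to propyl. Among the compounds with values here, the one measured step bearing on this is an at least 11-fold lower number from compound 1 to compound 2 (1.07 log units; beyond the scatter) from the same kind of change one bond closer to the nitrogen, and its size is open since it rests on the limit of > 100000 nM in this assay, at which 1 of the 2 values shown sits, alone. A smaller move in the same direction is therefore expected in this assay and may not clear the scatter. The estimated step is a 1.9-fold lower number from compound 2 to compound 3 (0.28 log units; within the scatter) for this chain extension. For compound 3 the expected value is 4500 nM with an estimated range from 1200 nM to 17000 nM in this assay here.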

Compound 3, half-maximal inhibitory concentration: 67500 nM
Estimate against measurement, compound 3: 15-fold (1.18 log units) below, and the stated range ends below it.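

Going from ethyl to propyl reverses the earlier gain in this assay, with an 8.0-fold higher number from compound 2 to compound 3 (0.90 log units; beyond the scatter), so the response to chain length at this position is not steady and ethyl stands out among the compounds shown. Measured against the hydrogen-to-ethyl gain, little is left for propyl, with an at least 1.4-fold lower number from compound 1 to compound 3 (0.17 log units; that floor lies within the scatter). That step rests on a limit held by compound 1: the limit of > 100000 nM in this assay, at which 1 of the 3 values shown sits. From the compounds shown here alone, whether a longer chain, or an amine or a carboxylic acid on this chain, would bring the number back towards that of compound 2 stays open.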